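Replacing a hydroxypyrrolidine on a barely active compound

This account rests on a few compounds, and the source may have more. Where it says the series, first, only, none or still open, it means among the compounds named here.

Measured in a functional assay on HeLa cells (Homo sapiens) for antiproliferative activity, read by CCK-8 assay, with a stated time of 48 h; on this read-out higher numbers stand for weaker inhibition and lower numbers for stronger inhibition:
compound 1 `COc1ccc(/C=C\c2cc(OC)c(OC)c(OC)c2)cc1OCc1ccc(CN2CCCC[C@H]2C(=O)O)cc1` gives > 10000 nM (a limit)
compound 2 `COc1ccc(/C=C\c2cc(OC)c(OC)c(OC)c2)cc1OCc1ccc(CN2CC[C@H](C(=O)O)C2)cc1` gives > 10000 nM (a limit)
compound 3 `COc1ccc(/C=C\c2cc(OC)c(OC)c(OC)c2)cc1OCc1ccc(CN2CC[C@H](O)C2)cc1` gives 10500 nM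

Within the data shown here, compound 3 holds the only true number in this set, 10500 nM. The other two entries are limits of the assay, not numbers.

Compound 4 `COc1ccc(/C=C\c2cc(OC)c(OC)c(OC)c2)cc1OCc1ccc(CNCCNC(C)=O)cc1` keeps the shared core and changes one group: (2-acetamidoethyl)amino in place of 3-hydroxypyrrolidin-1-yl on a saturated chain carbon bound to an aromatic carbon. In plain words, (2-acetamidoethyl)amino takes the place of 3-hydroxypyrrolidin-1-yl on a saturated chain carbon bound to an aromatic carbon, and the ring is gone.

The measured steps that bear on this change the same place: a step that the limit leaves unreadable from compound 1 to compound 3 and a step that the limit leaves unreadable from compound 2 to compound 3. Neither has a readable size, so they give no guide to how large a change here can be. The one firm observation is the limit of > 10000 nM in this assay, at which 2 of the 3 values shown sit.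

That leaves compound 3, with 10500 nM, as the only anchor, so no step beyond the usual scatter is expected in this assay, in either direction. The expected change is a 1.1-fold lower number from compound 3 to compound 4 (0.02 log units; within the scatter). For compound 4 the estimate is 10000 nM, with an expected range of 3000 nM to 30000 nM.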

Compound 4, half-maximal inhibitory concentration: 6400 nM
Estimate against measurement, compound 4: 1.6-fold (0.19 log units) above; measured number inside the range.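

In this assay, this position now has its first readable step: a 1.6-fold lower number from compound 3 to compound 4 (0.22 log units; within the scatter). The open (2-acetamidoethyl)amino chain carries no ring and no defined stereocentre, yet it leaves the number within the scatter of the value for the 3-hydroxypyrrolidin-1-yl compound, so for this pair a ring on the saturated chain carbon is not required to keep this level of activity. The steps among compound 1, compound 2 and compound 3 still cannot be read, and the two new steps from the carboxy compounds, an at least 1.5-fold lower number from compound 2 to compound 4 (0.19 log units; that floor lies within the scatter) and an at least 1.5-fold lower number from compound 1 to compound 4 (0.19 log units; that floor lies within the scatter), are only floors, because each starts from a limit: the limit of > 10000 nM in this assay, at which 2 of the 4 values shown sit.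

No step shown is read as beyond the scatter, so it remains open whether any group at this place can shift the number clearly. On these data alone, it also remains open which part of the chain matters, a question that a (2-aminoethyl)amino group, with a free primary amine in place of the acetamide, or a longer chain ending in the same acetamide could help to answer.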